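The source may report more compounds than this note shows. Statements on the series, on what has been measured and on what is new or still open speak of the compounds shown alone.

In a functional assay on U-87MG ATCC cells for inhibition, with U-87 MG (Homo sapiens) as the target, read by MTT assay, with a stated time of 72 h (on this read-out lower numbers stand for stronger inhibition and higher numbers for weaker inhibition), compound 1 `Cc1ccnc(NC(c2ccc(F)cc2)c2ccc3cccnc3c2O)c1` gives > 10000 nM, which is a limit of the assay and not a number. Compound 2 `Cc1ccnc(NC(c2cc(C)ccc2C)c2ccc3cccnc3c2O)c1` gives > 10000 nM, also a limit. The only thing known so far is therefore (the limit of > 10000 nM in this assay, at which 2 of the 2 values shown sit), and compound 1 offers no exact starting value.

Compound 3 `Oc1c(C(c2ccc(F)cc2)N2CCCCC2)ccc2cccnc12` keeps the shared core but changes one group: piperidin-1-yl in place of (4-methylpyridin-2-yl)amino on a saturated chain carbon bound to two aromatic carbons. In words, this puts piperidin-1-yl in place of (4-methylpyridin-2-yl)amino on a saturated chain carbon bound to two aromatic carbons.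

For the measured compounds named here, the one measured step, a step that the two limits leave unreadable from compound 1 to compound 2, concerns a different group and has no readable size, so it gives no guide to this change. Any readable result in this assay would have to lie on the stronger side of the limit, though another limit remains quite possible. The estimated step is an at least 1.6-fold lower number from compound 1 to compound 3 (0.22 log units; that floor lies within the scatter), towards stronger inhibition. Compound 3 is expected near 6000 nM, with an estimated range from 1500 nM to 20000 nM.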

Compound 3, half-maximal inhibitory concentration: 37000 nM
Compound 3: the middle estimate sits 6.2-fold (0.79 log units) below what was measured, outside the stated range (above it).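

Compound 1 gives only a limit of the assay and not a number, and the step from it to compound 3 cannot be read. The compounds shown leave open how large the change is, and in which direction, when piperidin-1-yl replaces (4-methylpyridin-2-yl)amino in this assay.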